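The compounds below may be only part of what the source reports. "The series", "measured", "known", "first", "only" and "open" are said of these compounds alone.

Measured so far in a physicochemical assay for lipophilicity, in phosphate buffer, measured as octanol-water partition; a lower number here means a more polar compound, a higher number a more lipophilic compound:
compound 1, `Cc1nc2ccccc2c(=O)n1/N=C/c1ccc(Oc2ccc3ccccc3c2)cc1`, gives 5.22
compound 2, `Cc1nc2ccccc2c(=O)n1/N=C/c1ccc(Oc2ccc(F)cc2)cc1`, gives 4.21
compound 3, `CCCc1nc2ccccc2c(=O)n1/N=C/c1ccc(Oc2ccc3ccccc3c2)cc1`, gives 6.12

Across these three, compound 3 stands highest; the step from compound 1 to compound 3 and the step from compound 1 to compound 2 are both beyond the scatter. The change 4-fluorophenyl in place of naphthalen-2-yl on an oxygen on an aromatic ring gave a number 1.01 log units lower from compound 1 to compound 2 (beyond the scatter). The two cores differ as follows: ethyl in place of hydrogen on a saturated chain carbon bound to an aromatic carbon, and this gave a number 0.90 log units higher from compound 1 to compound 3 (beyond the scatter).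

Compound 4, `CCCc1nc2ccccc2c(=O)n1/N=C/c1ccc(Oc2ccc(F)cc2)cc1`, has not yet been measured in this assay. It differs from compound 3 by 4-fluorophenyl in place of naphthalen-2-yl on an oxygen on an aromatic ring. The place of this change is described in the same words as the change from compound 1 to compound 2, so it is the same change; among the compounds shown it occurs twice in all.

The step from compound 3 to compound 4 is expected to be a number 1.01 log units lower from compound 3 to compound 4 (beyond the scatter), set beside the earlier one, because compound 1 to compound 2 gave a number 1.01 log units lower from compound 1 to compound 2 (beyond the scatter) and nothing among the compounds shown suggests the core of compound 3 would turn this step around. Compound 4 is therefore estimated at 5.11, expected to fall between 4.7 and 5.5.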

Compound 4, partition coefficient: 5.22
Estimate against measurement, compound 4: 0.11 log units below; measured number inside the range.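

In this assay, 4-fluorophenyl in place of naphthalen-2-yl gives a number 0.90 log units lower from compound 3 to compound 4 (beyond the scatter) on the ethyl-bearing core, alongside a number 1.01 log units lower from compound 1 to compound 2 (beyond the scatter) on the core without the ethyl, so the change keeps its direction on both cores. Read the other way, ethyl in place of hydrogen gives a number 1.01 log units higher from compound 2 to compound 4 (beyond the scatter) with 4-fluorophenyl present, alongside a number 0.90 log units higher from compound 1 to compound 3 (beyond the scatter) with naphthalen-2-yl present, and again the direction holds. This is a single square of four compounds in one assay, so it shows that the change carried over between these two cores only, not that it will carry to any other core, and nothing shown accounts for the result.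

The compounds shown leave open whether the direction of either step would survive on a core bearing a longer chain in place of the ethyl. They also leave open what an amine or a carboxylic acid in place of 4-fluorophenyl would do to this read-out.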